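The source may hold more compounds than are shown below. What is called first, only, known or untested is meant among the compounds shown, and "the series" means these compounds.

Measured compounds:
- compound 1, `CN(C)c1ccc(C(=O)N[C@@H](CCCCCC(=O)NO)C(=O)NCc2ccccc2)cc1`, 1600 nM
- compound 2, `CN(C)c1ccc(C(=O)N[C@H](CCCCCC(=O)NO)C(=O)NCc2ccccc2)cc1`, 160 nM
- compound 3, `CN(C)c1ccc(C(=O)NC(CCCCCC(=O)NO)C(=O)NCc2ccccc2)cc1`, 130 nM

In a functional assay on MM96L cells (Homo sapiens) for antiproliferative activity (on this read-out lower numbers stand for stronger inhibition and higher numbers for weaker inhibition), compound 1 gives 1600 nM, the highest of the three numbers, which means the weakest inhibition among them. Its nearest neighbour is compound 2, with a 10-fold lower number from compound 1 to compound 2 (1.00 log units; beyond the scatter), a step that rests on (the fact that compounds 1 and 2 differ only in the configuration as drawn). Compound 3 gives 130 nM, and a 12-fold lower number from compound 1 to compound 3 (1.09 log units; beyond the scatter); here the fact that one of compounds 1 and 3 is drawn with a defined configuration and the other without, at the place where they differ describes the only difference. Between compound 2 and compound 3, a 1.2-fold lower number from compound 2 to compound 3 (0.09 log units; within the scatter), with the fact that one of compounds 2 and 3 is drawn with a defined configuration and the other without, at the place where they differ as the only difference.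

Compound 4, `O=C(CCCCC[C@H](NC(=O)c1cc2ccccc2[nH]1)C(=O)NCc1ccccc1)NO`, is not yet measured. It differs from compound 1 in one place: 1H-indol-2-yl in place of 4-(dimethylamino)phenyl on a carbonyl carbon. The configuration at the chain stereocentre, the weaker one in compound 1, is kept. Going by the values given here, none of the measured steps touches the aromatic group on the carbonyl carbon; all three concern only the configuration of the chain stereocentre, so no measured step bears directly on this change. The hydroxamic acid chain and the benzylamide are kept, so a number of the same order as compound 1 is expected. For compound 4 the estimate in this assay is 900 nM, with a range from 150 nM to 5000 nM, which would correspond to a 1.8-fold lower number from compound 1 to compound 4 (0.25 log units; within the scatter).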

Compound 4, half-maximal inhibitory concentration: 250 nM
Estimate against measurement, compound 4: 3.6-fold (0.56 log units) above; low and high end bracket the measured number.
By their numbers in this assay, from the lowest: compounds 3, 2 and 4 (each within the scatter of the next); then compound 1.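

The group on the carbonyl carbon turns out to matter in this assay: with the chain stereocentre unchanged, 1H-indol-2-yl in place of 4-(dimethylamino)phenyl gives a 6.4-fold lower number from compound 1 to compound 4 (0.81 log units; beyond the scatter). Going by these compounds alone, until now, the only change seen to shift the number was the configuration at the chain stereocentre, so this is a second place in the molecule where a single change moves the result beyond the scatter. The two groups have the same count of heavy atoms, carbon and nitrogen, yet they differ in their rings and in their hydrogen-bond donors and acceptors, and nothing measured here explains why the number falls.

From the compounds shown here alone, it remains open whether the step depends on the hydrogen-bond donor that enters, which could be tested with a 1-methyl-1H-indol-2-yl group or a plain phenyl on the same carbonyl carbon. Going by these compounds, it is also open whether inverting the chain stereocentre of compound 4 would lower the number further, as seen for the 4-(dimethylamino)phenyl series in a 10-fold lower number from compound 1 to compound 2 (1.00 log units; beyond the scatter), or whether the two changes do not add up.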